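A few compounds are considered here, and "the series" means these few. Any claim that something is new, unique, unknown or untested is made for them only; others in the source may bear on it.

Compound 1, `CN(C)C(=O)c1cc2cnc(Nc3ccc(S(=O)(=O)NCCCCN=C=S)cc3)nc2n1C1CCCC1`: in a functional assay on NCI-H1299 cells (Homo sapiens) for inhibition, read by CCK-8 assay, with a stated time of 72 h, tested at 10 uM (on this read-out higher numbers stand for a stronger effect at the one concentration tested and lower numbers for a weaker effect), compound 1 gives 72.7%.
Compound 2, `CN(C)C(=O)c1cc2cnc(Nc3ccc(S(=O)(=O)NCCCCCN=C=S)cc3)nc2n1C1CCCC1`: in this assay compound 2 gives 83.4%.
Compound 3, `CN(C)C(=O)c1cc2cnc(Nc3ccc(C(=O)NCCCCCCN=C=S)cc3)nc2n1C1CCCC1`: in this assay compound 3 gives 85%.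

Within the measured set, a group of 4 heavy atoms (2 carbon, 1 nitrogen, 1 sulfur; no ring) in place of a group of 3 heavy atoms (1 carbon, 1 nitrogen, 1 sulfur; no ring), on a saturated chain carbon, four bonds along the chain from a sulfonamide nitrogen gave a number 10.7 percentage points higher from compound 1 to compound 2 (beyond the scatter). The two cores differ by a group of 12 heavy atoms (8 carbon, 2 nitrogen, 1 oxygen, 1 sulfur; no ring) in place of a group of 11 heavy atoms (5 carbon, 2 nitrogen, 2 oxygen, 2 sulfur; no ring), on an aromatic carbon; between compound 2 and compound 3 the step is a number 1.6 percentage points higher from compound 2 to compound 3 (within the scatter).

Compound 4, `CN(C)C(=O)c1cc2cnc(Nc3ccc(C(=O)NCCCCCCCN=C=S)cc3)nc2n1C1CCCC1`, carries a group of 4 heavy atoms (2 carbon, 1 nitrogen, 1 sulfur; no ring) in place of a group of 3 heavy atoms (1 carbon, 1 nitrogen, 1 sulfur; no ring), on a saturated chain carbon, six bonds along the chain from an amide-type nitrogen. This is the same kind of change as in compound 1 to compound 2, but around a different place: there it sat four bonds along the chain from a sulfonamide nitrogen, here six bonds along the chain from an amide-type nitrogen. Resting on the step in a number 10.7 percentage points higher from compound 1 to compound 2 (beyond the scatter), a smaller rise is expected for compound 4, a number 3 percentage points higher from compound 3 to compound 4 (within the scatter), because compound 3 already stands at 85%. Compound 4 is thus estimated at 88%, between 78% and 95%.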

Compound 4, a percentage reported as inhibition, at one concentration (the size of the read-out at that concentration, not a potency): 107%
Estimate against measurement, compound 4: 19 percentage points below; measured number above the stated range.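

The swap of the group of 3 heavy atoms for the group of 4 heavy atoms also raises the read-out on the core of compound 3, giving a number 22 percentage points higher from compound 3 to compound 4 (beyond the scatter). The change therefore carries over in direction, and the two steps do not differ in size beyond what repeated measurement allows: the same change on two cores in this assay, a number 10.7 percentage points higher (beyond the scatter) from compound 1 to compound 2 and a number 22 percentage points higher (beyond the scatter) from compound 3 to compound 4, 11.3 percentage points apart, within the scatter of two such steps. This rests on one pair per core at a single concentration, so it does not show that the step has a fixed size or that it would hold on a third core.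

Still open, from the compounds shown here alone, is how a longer chain than that of compound 4 would read on either core. Also open, going by these compounds, is how an amine or a carboxylic acid at the chain end would compare.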